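Replacing One Aromatic Group at the Five-Membered Ring

A few compounds are considered here, and "the series" means these few. Any claim that something is new, unique, unknown or untested is made for them only; others in the source may bear on it.

Measured compounds:
compound 1, `O=C1COc2ccc(-c3[nH]c(-c4c[nH]c5ncccc45)nc3-c3ccccc3)cc2N1`, 111%
compound 2, `O=C1COc2ccc(-c3nn(-c4ccccc4)cc3-c3ccccc3)cc2N1`, 117%

Both measured compounds share the same core and were tested in a functional assay on MV4-11 cells (Homo sapiens) for cytotoxicity, read by colorimetric assay and MTT assay, with a stated time of 3 days, tested at 1 uM; on this read-out lower numbers stand for a stronger effect and higher numbers for a weaker effect at the one concentration tested. Compound 1 gives 111% in this assay, and compound 2 gives 117%. Compound 1 holds the lower of the two numbers, but the gap to compound 2 lies within the scatter, so the two values show no difference that can be read as an order.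

Compound 3, `O=C1COc2ccc(-c3[nH]c(-c4ccc(C(F)(F)F)cc4)nc3-c3ccccc3)cc2N1`, is not yet measured. It differs from compound 1 by a group of 10 heavy atoms (7 carbon, 3 fluorine; one six-membered aromatic ring of carbon only) in place of a group of 9 heavy atoms (7 carbon, 2 nitrogen; one five-membered aromatic ring with 1 hetero atom, one six-membered aromatic ring with 1 hetero atom), on an aromatic carbon, the new group sitting between two ring nitrogen atoms. Going by the values given here, no step between measured compounds is available to guide the expectation. The estimated step of a number 6 percentage points lower from compound 1 to compound 3 (within the scatter) is expected to stay within the scatter, since compound 1 with 111% shows no effect at this concentration. Compound 3 is therefore expected to give 105%, with a range from 80% to 125%.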

Compound 3, a percentage reported as activity, at one concentration (the size of the read-out at that concentration, not a potency): 111%
Compound 3: the middle estimate sits 6 percentage points below what was measured; low and high end bracket the measured number.
By their numbers in this assay, from the lowest: compounds 1, 3 and 2 (each within the scatter of the next).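

Exchanging the group on the aromatic carbon of the five-membered ring with 2 nitrogen for 4-(trifluoromethyl)phenyl gives, in this assay, no change at the digits printed from compound 1 to compound 3 (within the scatter) at the one concentration tested. Going by these compounds alone, this is the first direct comparison at this position: the group that leaves carries a hydrogen-bond donor and a hydrogen-bond acceptor and the group that enters carries neither, yet the number stays put. With both compounds at a level that shows no effect, however, the step cannot tell whether the position tolerates the change or is simply silent in this read-out. Nothing at hand explains this result.

The compounds shown leave open whether any group at this carbon can bring the number down. An amine or a carboxylic acid on the phenyl ring, or a simple methyl in its place, would test this.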